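Anilino for benzylamino on the shared core

The source may report more compounds than this note shows. Statements on the series, on what has been measured and on what is new or still open speak of the compounds shown alone.

Of the compounds shown here, two have been tested in an ADME assay on L02 cells (Homo sapiens) for inhibition, read by CCK-8 assay, with a stated time of 48 h; a lower number here means a stronger inhibitor of growth, a higher number a weaker inhibitor of growth. Compound 1 `Cc1ccccc1Nc1nc(Nc2ccccc2)ncc1Cl` carries a methylphenyl and a phenyl on the two ring nitrogens of the shared core. In this assay compound 1 reaches only the limit of the measurement, > 100000 nM, and gives no number. Compound 2 `CN1CCN(c2ccc(Nc3ncc(Cl)c(NCc4ccccc4)n3)nc2)CC1` bears a benzyl on one nitrogen and a methylpiperazinyl-substituted pyridyl on the other. In this assay, going by the values given here, compound 2 gives 20300 nM, the only finite number in the set, as the other value sits at the limit of > 100000 nM in this assay, at which 1 of the 2 values shown sits.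

Compound 3 `COc1ccc(Nc2nc(Nc3ccc(N4CCN(C)CC4)cn3)ncc2Cl)cc1` is the next step from compound 2. The change is 4-methoxyphenyl in place of benzyl on a nitrogen on an aromatic ring. Among the compounds with values here, since no pair of measured compounds is separated by a single change of this kind, there is no measured step on which to lean. The step from compound 2 to compound 3 is expected to be small, within the usual scatter, as a 1.4-fold lower number from compound 2 to compound 3 (0.13 log units; within the scatter). Compound 3 is therefore estimated at 15000 nM, in a range from 4000 nM to 60000 nM.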

Compound 3, concentration for 50% growth inhibition: 3150 nM
Beside the measured number, compound 3's estimate is 4.8-fold (0.68 log units) above it; the measured number lies below the stated range.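

The group on this nitrogen clearly matters in this assay: with the methylpiperazinyl-substituted pyridyl on the other nitrogen left in place, benzylamino to (4-methoxyphenyl)amino gives a 6.4-fold lower number from compound 2 to compound 3 (0.81 log units; beyond the scatter). Going by these compounds alone, this is the first step that can be read as a single change, and it runs towards stronger inhibition of growth in L02 cells, the cell line here used as the ADME read-out. The swap alters more than one feature at once, since the entering group carries an oxygen and a hydrogen-bond acceptor that benzyl lacks, and nothing measured here gives a reason for the size of the step.

Going by these compounds, what remains open is whether the methoxy group itself matters or whether the gain comes with any aryl group set directly on this nitrogen, a question that a 4-hydroxyphenyl or a 4-(dimethylamino)phenyl in the same place would begin to address. The compounds shown hold only this one step, and the remaining comparison point is no number at all but a limit of the assay: the limit of > 100000 nM in this assay, at which 1 of the 3 values shown sits.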